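The source may report more compounds than this note shows. Statements on the series, on what has been measured and on what is new or still open speak of the compounds shown alone.

Measured in an ADME assay on L1210/0 cells (Mus musculus) for cytotoxicity, with a stated time of 48 h; on this read-out higher numbers stand for weaker inhibition and lower numbers for stronger inhibition:
- compound 1 `COc1ncnc2c1ncn2C[C@@H]1C[C@H](O)c2ccccc21`: > 200000 nM, a limit
- compound 2 `COC1=C(OCc2ccc([N+](=O)[O-])cc2)C(=O)O/C1=C\Cn1cnc2c(Cl)ncnc21`: 13600 nM
- compound 3 `Cc1cn(C[C@@H]2C[C@H](CO)c3ccccc32)c(=O)[nH]c1=O`: > 200000 nM, a limit

Compound 3 has no numerical value, and its reading of > 200000 nM is a limit. Compound 3 stands at the limit of > 200000 nM in this assay, at which 2 of the 3 values shown sit. Only compound 2 gives a number, 13600 nM.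

Compound 4 `O=c1ccn(C[C@@H]2C[C@H](CO)c3ccccc32)c(=O)[nH]1` carries hydrogen in place of methyl on an aromatic carbon of compound 3 (hydrogen in place of methyl on an aromatic carbon). Among the compounds with values here, no measured pair shows this change. The expectation therefore rests on compound 3, whose limit is > 200000 nM. Within the data shown here, the estimated change is a number no higher from compound 3 to compound 4 (the limit leaves the size open), with no step expected beyond the usual scatter in this assay. Compound 4 is expected at 200000 nM, with an estimated range of 80000 nM to 400000 nM.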

Compound 4, half-maximal inhibitory concentration: > 200000 nM
Compound 4: no number, only a limit; the forecaster's own chance of this, stated with the estimate: 85%; the middle value sits exactly at the limit.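

No step can be read from compound 3 to compound 4, since both readings are limits: the limit of > 200000 nM in this assay, at which 3 of the 4 values shown sit.
The compounds shown leave open whether hydrogen in place of methyl on an aromatic carbon changes the cytotoxicity of this pair at all.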